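This account rests on a few compounds, and the source may have more. Where it says the series, first, only, none or still open, it means among the compounds named here.

Working notes on the series, step from compound 2 to compound 4.

The measured set shares one core. Compound 1 `COc1cc2c(cc1OC)CN(c1ccc(C=O)cc1)CC2` in an ADME assay on Caco-2 cells (Homo sapiens) for permeability, read by LC-MS, with a stated time of 2 h, tested at 25 uM (a higher number here means that the compound crosses the layer faster, a lower number that the compound crosses the layer more slowly), gives 2.8 10^-6 cm/s. Compound 2 `COc1cc2c(cc1OC)CN(c1ccc(F)cc1)CC2` in this assay gives 20.4 10^-6 cm/s, the higher of the two numbers obtained so far. The remaining value is not a number: for compound 3 `COc1cc2c(cc1OC)CN(c1cc(C(F)(F)F)cc(C(F)(F)F)c1)CC2` the read-out in this assay is given only as the limit < 0.1 10^-6 cm/s, so that one of the three results recorded sits at the limit of < 0.1 10^-6 cm/s in this assay, at which 1 of the 3 values shown sits.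

For the measured compounds named here, the single one-place step among the measured compounds is a 7.3-fold higher number from compound 1 to compound 2 (0.86 log units; beyond the scatter).

Compound 4 `COc1cc2c(cc1OC)CN(c1ccccn1)CC2` is not yet measured. Its difference from compound 2 is pyridin-2-yl in place of 4-fluorophenyl on an amine nitrogen in a ring. Going by the values given here, no measured step matches this exchange; the only step recorded concerns a substituent on the aryl ring rather than replacement of the aryl ring itself, so it gives direction only loosely. The exchange keeps the size of the ring and adds one acceptor, as counted above; a modest decrease is the expectation, within or close to the scatter.

Compound 4 is therefore expected to give 12 10^-6 cm/s, with a range from 5 10^-6 cm/s to 25 10^-6 cm/s. This estimate means a step of a 1.7-fold lower number from compound 2 to compound 4 (0.23 log units; within the scatter).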

Compound 4, apparent permeability in the Caco-2 assay: 38.8 10^-6 cm/s
Compound 4: the middle estimate sits 3.2-fold (0.51 log units) below what was measured; measured number outside the range, above it.
By their numbers in the Caco-2 assay, from the lowest: compound 1; then compounds 2 and 4 (each within the scatter of the next). At a limit, below all of these: compound 3.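

In the Caco-2 assay the exchange of the whole aryl ring gives a 1.9-fold higher number from compound 2 to compound 4 (0.28 log units; within the scatter), whereas the earlier step concerned only a substituent on that ring; for this pair, therefore, the ring on the amine nitrogen can be 4-fluorophenyl or pyridin-2-yl with a difference that stays within the scatter. In a physicochemical assay for solubility, read by LC-MS, in phosphate buffer, with a stated time of 20 min, at pH 7.0, tested at 100 uM (on this read-out lower numbers stand for lower solubility and higher numbers for higher solubility), compound 2 gives 20300 nM and compound 4 gives 800 nM. The step in the physicochemical assay is a 25-fold lower number from compound 2 to compound 4 (1.40 log units; beyond the scatter), so the two read-outs do not move together for this pair.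

The compounds shown leave open whether a pyrimidine ring in the same place would match compound 4 in the Caco-2 assay. Also open, as far as these compounds go, is whether an amine or a hydroxyl group on the pyridin-2-yl ring would shift the number in the physicochemical assay.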